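A few compounds are considered here, and "the series" means these few. Any claim that something is new, unique, unknown or untested is made for them only; others in the source may bear on it.

Measured so far in a functional assay on HeLa cells (Homo sapiens) for antiproliferative activity, read by MTT assay; on this read-out higher numbers stand for weaker inhibition and lower numbers for stronger inhibition:
- compound 1 `CCOC(=O)C1=C(Cn2cc(COc3ccccc3C3NC(=O)NC(CCl)=C3C(=O)OCC)nn2)NC(=O)NC1c1ccccc1F` gives 18000 nM 
- compound 2 `CCOC(=O)C1=C(Cn2cc(COc3ccccc3C3NC(=O)NC(CCl)=C3C(=O)OCC)nn2)NC(=O)NC1c1ccc([N+](=O)[O-])cc1` gives 18000 nM 

Level with compound 1 at the digits shown, compound 2 reads 18000 nM and is the starting point for the next step.

Compound 3 `CCOC(=O)C1=C(Cn2cc(COc3ccccc3C3NC(=O)NC(CCl)=C3C(=O)OCC)nn2)NC(=O)NC1c1ccc(O)c(OC)c1` has not yet been measured. It carries 4-hydroxy-3-methoxyphenyl in place of 4-nitrophenyl on a saturated ring carbon, and the rest of the molecule is unchanged: 4-hydroxy-3-methoxyphenyl in place of 4-nitrophenyl on a saturated ring carbon.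

Going by the values given here, one measured step bears on this change, an exchange of one substituted phenyl group for another on the same saturated ring carbon: no change at the digits printed from compound 1 to compound 2 (within the scatter). That step lies within the scatter. Among the compounds with values here, it is a single step, and no measured compound yet carries a hydroxy or methoxy group on this phenyl ring, so the basis for the expectation is thin. No step beyond the scatter is therefore expected in this assay, and no direction is favoured.

The expected step is no change at the digits printed from compound 2 to compound 3 (within the scatter).

Compound 3 is estimated at 18000 nM, with an expected range from 8000 nM to 38000 nM.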

Compound 3, half-maximal inhibitory concentration: 18000 nM
For compound 3 middle estimate and measured number coincide at the digits printed, and the stated range covers the measured number.
By their numbers in this assay, from the lowest: compounds 1, 2 and 3 (each within the scatter of the next).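

Exchanging 4-nitrophenyl for 4-hydroxy-3-methoxyphenyl on the saturated ring carbon gives no change at the digits printed from compound 2 to compound 3 (within the scatter) in this assay and extends the earlier picture to an entering group that carries a hydrogen-bond donor, where the leaving group carries none. Set against the 2-fluorophenyl compound, the same group gives no change at the digits printed from compound 1 to compound 3 (within the scatter) so the three substituted phenyl groups at this position, with fluoro, nitro, or hydroxy and methoxy substituents, all read alike in this assay and no substituent among them separates from the others. Nothing at hand offers an explanation for this flat reading.

The compounds shown leave open whether anything at this position can shift the number, for instance a carboxylic acid or a dimethylamino group on the phenyl ring, or a longer alkyl chain in place of the ring altogether. All three compounds also share the remainder of the molecule unchanged, so how much of the common level rests on that remainder rather than on this position stays unresolved.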